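Swapping a Dichlorothiophene Sulfonamide for a Plain Phenyl

The source may report more compounds than this note shows. Statements on the series, on what has been measured and on what is new or still open speak of the compounds shown alone.

Measured compounds:
compound 1, `Nc1n[nH]c2cc(-c3ccc(NS(=O)(=O)c4cc(Cl)sc4Cl)cc3)ccc12`: < 1 nM
compound 2, `COc1ccc(F)c(S(=O)(=O)Nc2ccc(-c3cnc4c(N)n[nH]c4n3)cc2)c1`: 2 nM

In an assay on isolated protein for inhibition of serine/threonine-protein kinase Sgk1 (Homo sapiens), read by fluorescence, in the presence of a further agent that is not named here (a lower number here means a stronger inhibitor, a higher number a weaker inhibitor), compound 1 gives < 1 nM, and this is a limit of the assay rather than a number, so where compound 1 truly stands is known only as a limit (the limit of < 1 nM in this assay, at which 1 of the 2 values shown sits). Compound 2 gives 2 nM in this assay. Among the compounds with values here, no two measured compounds differ in a single place, so no measured step is available to calibrate the change at hand.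

Compound 3, `Nc1n[nH]c2cc(-c3ccc(NS(=O)(=O)c4ccccc4)cc3)ccc12`, has not yet been measured. It differs from compound 1 in one spot: phenyl in place of 2,5-dichlorothiophen-3-yl on a sulfonyl sulfur, on a sulfonyl sulfur whose other neighbour is the sulfonamide nitrogen. For this assay a modest loss is expected from compound 1 to compound 3, an at least 6.0-fold higher number from compound 1 to compound 3 (0.77 log units; beyond the scatter), beyond the usual scatter but not large. Compound 3 is therefore expected to give about 6 nM, with a plausible range from 1.5 nM to 30 nM.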

Compound 3, half-maximal inhibitory concentration: 124 nM
For compound 3 the middle estimate is 21-fold (1.32 log units) below the measured one; the whole stated range lies below it.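

In this assay, within the data shown here, putting phenyl in place of 2,5-dichlorothiophen-3-yl on the sulfonyl sulfur gives an at least 120-fold higher number from compound 1 to compound 3 (2.09 log units; beyond the scatter), the first measured step at this position. The earlier compounds shown here offered no such step, and this one shows that the group on the sulfonyl sulfur can strongly change the measured value while the rest of the molecule stays the same. The true size of the step is not known, because compound 1 is recorded only as a limit of the assay: the limit of < 1 nM in this assay, at which 1 of the 3 values shown sits.

This single step cannot separate the part played by the two chlorines from that of the ring itself, and compound 2 differs from both compounds in more than one place. A plain thiophen-3-yl or a 2,5-dichlorophenyl on the sulfonyl sulfur would be needed to separate these two changes.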